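This account rests on a few compounds, and the source may have more. Where it says the series, first, only, none or still open, it means among the compounds named here.

Measured compounds:
Compound 1 `COc1cc(Cl)cc(-c2nn(-c3cccc(NC(=O)Nc4ccc(Cl)c(C(F)(F)F)c4)c3)cc2-c2ccncc2)c1` — in a functional assay on K562 cells (Homo sapiens) for inhibition, read by sulforhodamine B assay, with a stated time of 48 h, tested at 0.1 uM (a higher number here means a weaker effect of the compound at the concentration tested, a lower number a stronger effect), compound 1 gives 91%.
Compound 2 `COc1cc(Cl)cc(-c2nn(-c3cccc(NC(=O)c4cccc(C(F)(F)F)c4)c3)cc2-c2ccncc2)c1` — in this assay compound 2 gives 112%.
Compound 3 `O=C(Nc1cccc(-n2cc(-c3ccncc3)c(-c3cc(O)cc(Cl)c3)n2)c1)Nc1ccc(Cl)c(Cl)c1` — in this assay compound 3 gives 100%.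

Compound 3 stands second highest of the three numbers in this assay. Its nearest neighbour is compound 1, whose number is lower but within the scatter, so the two cannot be ordered; compound 2 lies higher than compound 3, beyond the scatter.

Compound 4 `COc1cc(Cl)cc(-c2nn(-c3cccc(NC(=O)Nc4ccc(Cl)c(Cl)c4)c3)cc2-c2ccncc2)c1` has not yet been measured. It differs from compound 3 in one place: methyl in place of hydrogen on an oxygen on an aromatic ring. Among the compounds with values here, the only measured step, a number 21 percentage points higher from compound 1 to compound 2 (beyond the scatter), concerns the carbonyl side of the molecule and does not touch the oxygen on the aromatic ring, so it does not bear on this change. Compounds 1 and 3, which carry methoxy and hydroxy on that ring but also differ elsewhere, show numbers within the scatter of each other. Compound 4 is therefore expected to give 97% in this assay, a step of a number 3 percentage points lower from compound 3 to compound 4 (within the scatter) that is expected to stay within the scatter, with a range from 82% to 112%.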

Compound 4, a percentage reported as activity, at one concentration (the size of the read-out at that concentration, not a potency): 58%
The estimate for compound 4 lay 39 percentage points above the measured number; the whole stated range lies above it.
By their numbers in this assay, from the lowest: compound 4; then compounds 1 and 3 (each within the scatter of the next); then compound 2.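

In this assay, within the data shown here, the step of a number 42 percentage points lower from compound 3 to compound 4 (beyond the scatter) gives the first single-change reading at this oxygen: with the rest of the molecule held constant, methoxy gives a much stronger effect at the tested concentration than hydroxy. The step of a number 33 percentage points lower from compound 1 to compound 4 (beyond the scatter) shows that, with methoxy kept, chloro in place of trifluoromethyl on an aromatic carbon also carries a large change, so compound 4 owes its number to more than the oxygen substituent alone. The step of a number 54 percentage points lower from compound 2 to compound 4 (beyond the scatter), for (3,4-dichlorophenyl)amino in place of 3-(trifluoromethyl)phenyl on a carbonyl carbon, leaves compound 4 with the lowest number of the four.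

As far as these compounds go, whether ethoxy, a longer chain, or an amine at this place would lower the number further remains open. Nothing available explains why these steps are so large.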